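Amide Substituents on a Shared Dienamide Chain

This account rests on a few compounds, and the source may have more. Where it says the series, first, only, none or still open, it means among the compounds named here.

Measured compounds in a functional assay on A549 cells (Homo sapiens) for antiproliferative activity, read by sulforhodamine B assay, with a stated time of 48 h; a higher number here means a weaker inhibitor, a lower number a stronger inhibitor:
compound 1, `CCNC(=O)/C=C/C=C/[C@H](O)Cc1ccc(OC)c(OC)c1`, gives 13800 nM
compound 2, `COc1ccc(C[C@@H](O)/C=C/C=C/C(=O)N2CCCCC2)cc1OC`, gives 16400 nM
compound 3, `COc1ccc(C[C@@H](O)/C=C/C=C/C(=O)N2CCN(C)CC2)cc1OC`, gives 22200 nM

Compound 2 sits second highest of the three numbers in this assay. Its nearest neighbour is compound 1, by a 1.2-fold higher number from compound 1 to compound 2 (0.07 log units; within the scatter), and its furthest is compound 3, by a 1.4-fold higher number from compound 2 to compound 3 (0.13 log units; within the scatter); both steps lie within the scatter, as does a 1.6-fold higher number from compound 1 to compound 3 (0.21 log units; within the scatter). On these numbers the three amides cannot be told apart.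

The unmeasured compound 4, `CCN1CCN(C(=O)/C=C/C=C/[C@H](O)Cc2ccc(OC)c(OC)c2)CC1`, differs from compound 2 in one place: 4-ethylpiperazin-1-yl in place of piperidin-1-yl on a carbonyl carbon.

The step that bears most directly on this change is a 1.4-fold higher number from compound 2 to compound 3 (0.13 log units; within the scatter), where a 4-methylpiperazin-1-yl replaces the same piperidin-1-yl on the carbonyl carbon and the number stays within the scatter. Compound 4 carries the 4-ethylpiperazin-1-yl instead, a change of one more carbon on the chain than in compound 3. Within the data shown here, nothing among the measured steps suggests that this should move the number beyond the scatter in either direction, so the expected step is a 1.2-fold higher number from compound 2 to compound 4 (0.09 log units; within the scatter), which is within the scatter.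

For compound 4 in this assay the estimated value is 20000 nM, with a range from 9000 nM to 45000 nM.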

Compound 4, half-maximal inhibitory concentration: 15700 nM
Compound 4: the middle estimate sits 1.3-fold (0.11 log units) above what was measured; the range from low to high includes it.
By their numbers in this assay, from the lowest: compounds 1, 4, 2 and 3 (each within the scatter of the next).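

In this assay, the step from piperidin-1-yl to 4-ethylpiperazin-1-yl on the carbonyl carbon, a 1.0-fold lower number from compound 2 to compound 4 (0.02 log units; within the scatter), shows that a second ring nitrogen carrying an ethyl group leaves compound 4 indistinguishable from the piperidine amide. Lengthening the substituent on that ring nitrogen from methyl to ethyl, a 1.4-fold lower number from compound 3 to compound 4 (0.15 log units; within the scatter), and setting the ring amide against the open ethylamino amide, a 1.1-fold higher number from compound 1 to compound 4 (0.06 log units; within the scatter), also stay within the scatter, so all four amides on the shared chain now form one group with no compound going against it. No measurement at hand bears on why these changes leave the number in place.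

From the compounds shown here alone, it remains open whether a morpholin-4-yl or a 4-benzylpiperazin-1-yl on the carbonyl carbon, or a carboxylic acid in place of the amide, would separate from this group. Also open, going by these compounds, is whether the four amides would stay together once the hydroxyl group or the two methoxy groups of the shared core are changed, since every compound here carries them unaltered.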